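This account rests on a few compounds, and the source may have more. Where it says the series, first, only, none or still open, it means among the compounds named here.

In a functional assay on MKN-45 cells (Homo sapiens) for antiproliferative activity, read by CellTiter-Glo, with a stated time of 3 days (a higher number here means a weaker inhibitor, a lower number a stronger inhibitor), compound 1 `CC(Oc1c(N)ncc2c(-c3cnn(C4CCNCC4)c3)coc12)c1c(Cl)cccc1Cl` gives 2000 nM, compound 2 `CC(Oc1c(N)ncc2c(-c3cnn(C4CCNCC4)c3)coc12)c1cc(F)ccc1Cl` gives 6400 nM and compound 3 `CC(Oc1c(N)ncc2c(-c3cnn(C4CCNCC4)c3)coc12)c1cccc(F)c1Cl` gives 5100 nM. Compound 3 therefore stands at the high end of these numbers, and its gap to its nearest neighbour is a 1.3-fold lower number from compound 2 to compound 3 (0.10 log units; within the scatter). Leaving the 2,6-dichlorophenyl group gave modest steps: a 3.2-fold higher number from compound 1 to compound 2 (0.51 log units; beyond the scatter) and a 2.6-fold higher number from compound 1 to compound 3 (0.41 log units; beyond the scatter). Compound 4 `CC(Oc1c(N)ncc2c(-c3cnn(C4CCNCC4)c3)coc12)c1c(Cl)ccc(Cl)c1Cl` differs from compound 3 as follows: a group of 9 heavy atoms (6 carbon, 3 chlorine; one six-membered aromatic ring of carbon only) in place of a group of 8 heavy atoms (6 carbon, 1 fluorine, 1 chlorine; one six-membered aromatic ring of carbon only), on a saturated chain carbon bound to an oxygen on an aromatic ring and a saturated chain carbon. For the measured compounds named here, the entering group carries chlorine and no fluorine, as does the group of compound 1 at 2000 nM, but no measured compound carries this exact group. A modest step to a lower number is expected, namely a 2.3-fold lower number from compound 3 to compound 4 (0.37 log units; beyond the scatter). Compound 4 is estimated at 2200 nM, with an expected range of 800 nM to 6000 nM.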

Compound 4, half-maximal inhibitory concentration: 1300 nM
Compound 4: middle estimate off by 1.7-fold (0.23 log units), on the high side, and the stated range covers the measured number.
By their numbers in this assay, from the lowest: compounds 4 and 1 (each within the scatter of the next); then compounds 3 and 2 (each within the scatter of the next).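

In this assay, chloro in place of hydrogen on an aromatic carbon gives only a 1.5-fold lower number from compound 1 to compound 4 (0.19 log units; within the scatter), so a third chlorine on the phenyl group leaves the number where the 2,6-dichlorophenyl group had it. Against the two groups carrying fluorine the trichlorinated group stands clearly apart, with a 3.9-fold lower number from compound 3 to compound 4 (0.59 log units; beyond the scatter) and a 4.9-fold lower number from compound 2 to compound 4 (0.69 log units; beyond the scatter), and among these four compounds both groups carrying only chlorine give lower numbers than both carrying fluorine. Nothing shown here explains this difference. On these data alone, whether bromo, methyl or methoxy in place of that added chloro would hold the number remains open, as does whether the ring needs chlorine at all.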